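The source may report more compounds than this note shows. Statements on the series, on what has been measured and on what is new or still open speak of the compounds shown alone.

Three compounds sharing one core have numbers in a functional assay on MDA-MB-435 cells (Homo sapiens) for inhibition; a higher number here means a weaker inhibitor, a lower number a stronger inhibitor. Compound 1 `COc1cc[nH]c1/C=C1\C(=O)Nc2ccc(F)c(C#C[C@H](C)O)c21` gives 190 nM, compound 2 `CN[C@H](C#Cc1c(F)ccc2c1/C(=C/c1[nH]ccc1OC)C(=O)N2)CO` gives 349 nM, and compound 3 `CN[C@H](C#Cc1c(F)ccc2c1/C(=C/c1[nH]ccc1OC)C(=O)N2)[C@@H](C)O` gives 358 nM. Every gap among the three lies within the scatter, so compound 3 stands level with the other two. Compound 4 `COc1cc[nH]c1/C=C1\C(=O)Nc2ccc(F)c(C#C[C@@H]3C[C@H](O)CN3)c21` differs from compound 3 by one change, 4-hydroxypyrrolidin-2-yl in place of 2-hydroxy-1-(methylamino)propyl on a triple-bonded carbon. The measured steps that bear on it were made at this same place: a 1.8-fold higher number from compound 1 to compound 2 (0.26 log units; within the scatter), a 1.9-fold higher number from compound 1 to compound 3 (0.28 log units; within the scatter) and a 1.0-fold higher number from compound 2 to compound 3 (0.01 log units; within the scatter). All three are small and stay within the scatter, so this assay has so far shown little response to changes at this place. Going by the values given here, none of them forms a ring, however, and the data hold no direct precedent for that feature. The expected step is therefore a 1.1-fold lower number from compound 3 to compound 4 (0.05 log units; within the scatter), with nothing expected beyond the scatter. Compound 4 is estimated at 320 nM, with an expected range from 120 nM to 850 nM.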

Compound 4, half-maximal inhibitory concentration: 110 nM
Compound 4: middle estimate off by 2.9-fold (0.46 log units), on the high side, and the stated range ends above it.
By their numbers in this assay, from the lowest: compounds 4, 1, 2 and 3 (each within the scatter of the next, the first and the last beyond it).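

In this assay, going by these compounds alone, the 4-hydroxypyrrolidin-2-yl group gives the first steps at this position that pass beyond the scatter, with a 3.3-fold lower number from compound 3 to compound 4 (0.51 log units; beyond the scatter) and with a 3.2-fold lower number from compound 2 to compound 4 (0.50 log units; beyond the scatter) as well. The position therefore does respond to change, yet the effect shows only against the two open chains carrying a methylamino group, since a 1.7-fold lower number from compound 1 to compound 4 (0.24 log units; within the scatter) leaves compound 4 level with the 1-hydroxyethyl compound 1. The entering and leaving groups match in heavy atoms, hydrogen-bond donors and acceptors and differ in the five-membered ring, but no measurement here explains the lower number.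

From the compounds shown here alone, it remains open whether the ring alone carries this step or whether its hydroxyl and two defined stereocentres share in it. An unsubstituted pyrrolidin-2-yl, the opposite stereoisomers of compound 4 and a six-membered piperidine ring would each bear on that question.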